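The source may hold more compounds than are shown below. What is called first, only, known or untested is meant among the compounds shown, and "the series" means these compounds.

Two compounds of this series have been examined in an ADME assay on the whole organism for pharmacokinetics, with Rattus norvegicus as the target, at a dose of 3 mg/kg by the oral route; on this read-out higher numbers stand for higher exposure at the dose given and lower numbers for lower exposure. Compound 1 `COC(=O)N[C@H](C(=O)N1CCC[C@H]1C(=O)Nc1ccc([C@@H]2CC[C@@H](c3ccc(NC(=O)[C@@H]4CCCN4C(=O)[C@@H](NC(=O)OC)[C@@H](C)OC)cc3)N2c2ccc(F)cc2)cc1)[C@@H](C)OC` gives 78.8 nM in this assay. Compound 2 `COC(=O)N[C@H](C(=O)N1CCC[C@H]1C(=O)Nc1ccc([C@@H]2CC[C@@H](c3ccc(NC(=O)[C@@H]4CCCN4C(=O)[C@@H](NC(=O)OC)[C@H]4CCOC4)cc3)N2c2ccc(F)cc2)cc1)[C@H]1CCOC1` gives 21.9 nM in this assay, the lower of the two numbers; compound 1 sits a good deal higher, and the gap between them lies beyond the usual scatter. For the measured compounds named here, as no step between two measured compounds that differ in a single place is available, the pair tells nothing about how any one change acts on exposure.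

Compound 3 `COC(=O)N[C@H](C(=O)N1CCC[C@H]1C(=O)Nc1ccc([C@H]2CC[C@H](c3ccc(NC(=O)[C@@H]4CCCN4C(=O)[C@@H](NC(=O)OC)[C@H]4CCOC4)cc3)N2c2ccc(F)cc2)cc1)[C@H]1CCOC1` is the next compound to be measured in this assay. Compared with compound 2, (the two compounds have the same atoms and bonds and differ only in configuration as drawn: 2 of 8 stereo elements differ; a stereocentre at a saturated ring carbon is drawn S in compound 2 and R in compound 3; a stereocentre at a saturated ring carbon is drawn S in compound 2 and R in compound 3). Going by the values given here, since compound 3 keeps every atom and bond of compound 2 and differs only in the configuration drawn at two saturated ring carbons, there is no measured step to lean on, and the direction of any change cannot be read from the data. The expectation is therefore a step of a 1.1-fold lower number from compound 2 to compound 3 (0.04 log units; within the scatter) that may fall either way, with a broad range. On that basis compound 3 is estimated at 20 nM in this assay, between 5 nM and 80 nM.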

Compound 3, maximal plasma concentration in the Rattus norvegicus assay: 32.9 nM
For compound 3 the middle estimate is 1.6-fold (0.22 log units) below the measured one, within the range that was stated.
By their numbers in the Rattus norvegicus assay, from the lowest: compounds 2 and 3 (each within the scatter of the next); then compound 1.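

In the Rattus norvegicus assay compound 2 gives 21.9 nM and compound 3 gives 32.9 nM. For the compounds shown here, in the Rattus norvegicus assay there is now a first readable step: a 1.5-fold higher number from compound 2 to compound 3 (0.18 log units; within the scatter), which lies within the scatter, so inverting the drawn configuration at these two saturated ring carbons gives no sign of a real shift in exposure for this pair. In a physicochemical assay for solubility, in phosphate buffer, measured as kinetic solubility, at pH 7.2 (a lower number here means a less soluble compound, a higher number a more soluble compound), compound 2 gives 9700 nM and compound 3 gives 8500 nM. In the physicochemical assay the same change gives a 1.1-fold lower number from compound 2 to compound 3 (0.06 log units; within the scatter), again within the scatter, so the two compounds cannot be told apart on either read-out. The comparison speaks for configuration alone and for no other structural change, because nothing enters or leaves between the two structures: the fact that compounds 2 and 3 differ only in the configuration as drawn.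

The two ring carbons change together here, so the compounds shown leave open what either one would do alone, and whether the same inversion would give a similar result with the side chains of compound 1. They also leave open how exposure and solubility would respond if a different group, such as an amine or a carboxylic acid, stood in place of the fluorine on the shared core.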